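From cyclohexyl to 1,1-dioxothiolan-3-yl: compound 3 and compound 4

A few compounds are considered here, and "the series" means these few. Any claim that something is new, unique, unknown or untested is made for them only; others in the source may bear on it.

Measured so far:
- compound 1 `CCc1nn(-c2ccc(F)cc2)c2c1CCN(c1cccc(C)c1)C2=O` gives 780 nM
- compound 2 `CCc1nn(C2CCCC2)c2c1CCN(c1ccccc1C)C2=O` gives 330 nM
- compound 3 `CCc1nn(C2CCCCC2)c2c1CCN(c1cccc(OC)c1)C2=O` gives 980 nM

In a functional assay on U-937 cells (Homo sapiens), read by cAMP accumulation (a lower number here means that less compound is needed, a higher number that more compound is needed for the effect), compound 3 gives 980 nM and lies within the scatter of compound 1 at 780 nM on this scale. Compound 2 at 330 nM needs less compound than compound 3, and that gap lies beyond the scatter.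

The next compound is compound 4 `CCc1nn(C2CCS(=O)(=O)C2)c2c1CCN(c1cccc(OC)c1)C2=O` which differs from compound 3 in one place. It has 1,1-dioxothiolan-3-yl in place of cyclohexyl on an aromatic nitrogen and keeps the rest of the structure. Among the compounds with values here, no measured compound carries this group, and no measured pair differs in this place alone, so the data offer no direct guide. The expectation is therefore loose. The step expected is towards a higher number, estimated as a 2.6-fold higher number from compound 3 to compound 4 (0.41 log units; beyond the scatter) with wide uncertainty. Compound 4 is estimated at 2500 nM in this assay with an expected range of 700 nM to 9000 nM around that figure.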

Compound 4, half-maximal effective concentration: 5270 nM
For compound 4 the middle estimate is 2.1-fold (0.32 log units) below the measured one, and the stated range covers the measured number.
By their numbers in this assay, from the lowest: compound 2; then compounds 1 and 3 (each within the scatter of the next); then compound 4.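

In this assay, the change on the aromatic nitrogen from cyclohexyl to 1,1-dioxothiolan-3-yl is a 5.4-fold higher number from compound 3 to compound 4 (0.73 log units; beyond the scatter). Within the data shown here, this is the only change here that can be read on its own, and it shows that the group at this place affects the number while the rest of the structure stays fixed. The entering group differs from cyclohexyl in ring size and ring atoms and brings 2 hydrogen-bond acceptors against 0, and no measurement here accounts for the rise.

Among these compounds, the single step cannot separate these differences, and how a tetrahydropyran-4-yl or an open isopropyl chain on the same nitrogen would compare remains open. From the compounds shown here alone, whether the same change has a similar effect alongside the other aromatic groups in compound 1 and compound 2 also remains unknown.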